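Swapping a benzyloxy arm for a stilbene-like arm

A few compounds are considered here, and "the series" means these few. Any claim that something is new, unique, unknown or untested is made for them only; others in the source may bear on it.

Measured compounds:
Compound 1 `Clc1ccc2[nH]c(SCc3ccccc3OCc3ccccc3)nc2c1`: 3%
Compound 2 `c1ccc(CCc2ccccc2CSc2ncc[nH]2)cc1`: 19%
Compound 3 `c1ccc(CSc2nc3ccccc3[nH]2)cc1`: -42%

Of the compounds shown here, three have been tested in an assay on isolated protein for inhibition of Indoleamine 2,3-dioxygenase 1 (Homo sapiens), with a stated time of 60 min, tested at 10 uM; on this read-out higher numbers stand for more inhibition at the one concentration tested (going by the name of the read-out) and lower numbers for less inhibition. Compound 2 gives 19%, compound 1 gives 3%, and compound 3 gives -42%. Compound 1 thus stands second of the three: the value of compound 2 lies above it by more than the usual scatter, and the value of compound 3 lies below it by a larger margin, again beyond the scatter. No single-change pairs exist among these three, so no measured step is available for comparison.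

Compound 4 `Clc1ccc2[nH]c(SCc3ccccc3/C=C/c3ccccc3)nc2c1` has not yet been tested in this assay. It differs from compound 1 in one place: 2-phenylethenyl in place of benzyloxy on an aromatic carbon. The change sits ortho to a large group, and the pair of phenyl-bearing arms of compound 4 resembles the arrangement in compound 2, which gives 19%. The unmeasured step is expected to be small, and the change from compound 1 to compound 4 is estimated as a number 7 percentage points higher from compound 1 to compound 4 (within the scatter), within the scatter. Compound 4 is estimated at 10%, with a range from -25% to 40%.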

Compound 4, a percentage reported as inhibition, at one concentration (the size of the read-out at that concentration, not a potency): -6%
The estimate for compound 4 lay 16 percentage points above the measured number; the measured number falls inside the stated range.
By their numbers in this assay, from the lowest: compound 3; then compounds 4 and 1 (each within the scatter of the next); then compound 2.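

In this assay, exchanging benzyloxy for 2-phenylethenyl on this aromatic carbon, ortho to a large group, gives a number 9 percentage points lower from compound 1 to compound 4 (within the scatter). At this place, then, the arm's oxygen and its one hydrogen-bond acceptor can give way to an all-carbon arm of the same heavy-atom count, with its double bond outside the aromatic rings, without a change in this read-out that exceeds the scatter. Nothing available accounts for this outcome.

The compounds shown leave open whether an amine, a carboxylic acid or a longer alkyl chain on this aromatic carbon would give a step beyond the scatter. They also leave open whether the same exchange would give a similar step on a different core.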